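The source may hold more compounds than are shown below. What is called first, only, known or untested is meant among the compounds shown, and "the series" means these compounds.

In a functional assay on Lewis lung carcinoma cells (Mus musculus) for antiproliferative activity, read by MTT assay, with a stated time of 24 h (on this read-out lower numbers stand for stronger inhibition and higher numbers for weaker inhibition), compound 1 `C=CCc1cc(-c2cccc(C(F)(F)F)c2)ccc1O` gives 65900 nM as a measured number. Compound 2 `C=CCc1cc(-c2ccccc2)ccc1O` gives > 100000 nM which is a limit of the assay and not a number. Compound 3 `C=CCc1cc(-c2cccc(SC)c2)ccc1O` differs from compound 2 by methylsulfanyl in place of hydrogen on an aromatic carbon with methylsulfanyl in place of hydrogen on an aromatic carbon. Within the data shown here, the one measured step that bears on this is an at least 1.5-fold higher number from compound 1 to compound 2 (0.18 log units; that floor lies within the scatter) where hydrogen replaces trifluoromethyl on an aromatic carbon. Only a small move toward a lower number is therefore expected, an at least 1.4-fold lower number from compound 2 to compound 3 (0.15 log units; that floor lies within the scatter) by this estimate. In this assay compound 3 is expected near 70000 nM with an estimated range from 30000 nM to 110000 nM around that figure.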

Compound 3, half-maximal inhibitory concentration: > 100000 nM
Compound 3: only a limit was reported; the forecaster's own chance of this, stated with the estimate: 40%; at least 1.4-fold (0.15 log units) between middle value and limit.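

In this assay, methylsulfanyl at this position, meta to a large group, yields no measured number: compound 3 ends at a limit of the assay, just as compound 2 does. Putting methylsulfanyl in place of trifluoromethyl gives an at least 1.5-fold higher number from compound 1 to compound 3 (0.18 log units; that floor lies within the scatter). The step joining the two limits cannot be read, because the assay runs out of range here: the limit of > 100000 nM in this assay, at which 2 of the 3 values shown sit.

As far as these compounds go, how far compound 2 and compound 3 lie beyond that limit stays open. Also open, from the compounds shown here alone, is whether an amine or a carboxylic acid at this position would give a measured number.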